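Working notes on compounds 1 to 4

The source may hold more compounds than are shown below. What is called first, only, known or untested is meant among the compounds shown, and "the series" means these compounds.

Measured so far:
compound 1 `CC/C(=C(\c1ccccc1)c1ccc(NC(=O)C(C)C)cc1)c1ccccc1`: > 30000 nM
compound 2 `CC/C(=C(/c1ccc(NC(=O)C(C)C)cc1)c1ccc(OC)cc1)c1ccccc1`: > 30000 nM
compound 3 `CC/C(=C(\c1ccc(NC(=O)C(C)C)cc1)c1ccc(OC)cc1)c1ccccc1`: 27900 nM

In a functional assay on MCF7 cells (Homo sapiens) for inhibition, read by trypan blue exclusion, with a stated time of 72 h (on this read-out higher numbers stand for weaker inhibition of growth and lower numbers for stronger inhibition of growth), compound 2 stands only at > 30000 nM, which is a limit of the assay and not a number. Compound 1 also sits at a limit in this assay. The step that the two limits leave unreadable from compound 1 to compound 2 cannot be read because of the limit of > 30000 nM in this assay, at which 2 of the 3 values shown sit. The step of an at least 1.0-fold lower number from compound 2 to compound 3 (0.03 log units; that floor lies within the scatter) lies within the scatter, as follows from the fact that compounds 2 and 3 differ only in the configuration as drawn. Compound 4 `CC/C(=C(\c1ccc(O)cc1)c1ccc(NC(=O)C(C)C)cc1)c1ccccc1` differs from compound 2 as hydrogen in place of methyl on an oxygen on an aromatic ring. Among the measured compounds shown here, no measured step touches this oxygen readably, so nothing here sets a direction. The step of a number no higher from compound 2 to compound 4 (the limit leaves the size open) is expected to stay within the scatter. Compound 4 is therefore estimated at 30000 nM, in a range from 5000 nM to 100000 nM.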

Compound 4, concentration for 50% growth inhibition: 14700 nM
For compound 4 the middle estimate is 2.0-fold (0.31 log units) above the measured one; the range from low to high includes it.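

In this assay compound 2 gives > 30000 nM as a limit and not a number, and compound 1 sits at the same limit. Methoxy to hydroxy gives an at least 2.0-fold lower number from compound 2 to compound 4 (0.30 log units; that floor lies within the scatter) and hydroxy in place of hydrogen gives an at least 2.0-fold lower number from compound 1 to compound 4 (0.30 log units; that floor lies within the scatter) as readable steps at this place, which the earlier compounds did not give. Both are floors only, so compound 4 comes off the limit, yet no step beyond the scatter is shown.

From the compounds shown here alone, the true size of both steps stays open. Also open, going by these compounds, is whether an amine or a carboxylic acid in place of the hydroxy would give a lower number than compound 4.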